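A few compounds are considered here, and "the series" means these few. Any claim that something is new, unique, unknown or untested is made for them only; others in the source may bear on it.

Of the compounds shown here, three built on one shared core have been measured in a functional assay on HeLa cells (Homo sapiens) for cytotoxicity, read by CCK-8 assay, with a stated time of 72 h; on this read-out lower numbers stand for stronger inhibition and higher numbers for weaker inhibition. Compound 1 `COc1ccccc1/C=c1/[nH]c(=O)/c(=C\c2cccc(Cl)c2Cl)[nH]c1=O` is reported in this assay as "not active" (no number reported), with no number given. Compound 3 `COc1ccccc1/C=c1\c(=O)[nH]/c(=C/c2cccc(Cl)c2Cl)c(=O)n1C` gives 200 nM in this assay. Compound 2 `C=CCn1c(=O)/c(=C\c2cc(Br)ccc2F)[nH]c(=O)/c1=C\c1ccccc1OC` gives 34600 nM in this assay; this is the higher of the two numbers, so compound 2 inhibits more weakly than compound 3, whose number stands far lower, well beyond the usual scatter.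

Compound 4 `C=CCn1c(=O)/c(=C\c2ccc(C)cc2)[nH]c(=O)/c1=C\c1ccccc1OC` has not yet been measured. It differs from compound 2 in one place: 4-methylphenyl in place of 5-bromo-2-fluorophenyl on a double-bonded chain carbon bound to an aromatic carbon. Within the data shown here, no pair of measured compounds differs in just one place, so no measured step shows what such an exchange does here; the wide gap between compound 2 and compound 3 involves several changes at once and cannot serve as a guide for this one.

The expectation for compound 4 therefore rests on compound 2 alone, and the step from compound 2 to compound 4 is expected to stay within the scatter, with no clear direction: a 1.2-fold lower number from compound 2 to compound 4 (0.06 log units; within the scatter). Compound 4 is estimated at 30000 nM in this assay, in a range from 5000 nM to 150000 nM, and there is a real chance that the assay reports it only as not active, without a number.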

Compound 4, half-maximal inhibitory concentration: "not active" (no number reported)
For compound 4 the study gives words and no number; no gap can be computed for the estimate.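

In this assay compound 4 gives "not active" (no number reported) and so, with no number beside that of compound 2, no new step can be read between these two compounds. The compounds shown leave open how far the exchange of 5-bromo-2-fluorophenyl for 4-methylphenyl shifts inhibition. No measurement shown here bears on this result.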